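Replacing a chlorophenyl arm with a furan ring

This account rests on a few compounds, and the source may have more. Where it says the series, first, only, none or still open, it means among the compounds named here.

Compound 1 `Cc1cc(O)c(C(C)C)cc1-c1cc(-c2ccccc2Cl)c(C#N)c(=O)[nH]1` gives 34% in a functional assay for inhibition, tested at 100 ug/mL; a lower number here means a weaker effect, a higher number a stronger effect of the compound at the concentration tested.
Compound 2 `COc1ccc(-c2cc(-c3cc(C(C)C)c(O)cc3C)[nH]c(=O)c2C#N)c(OC)c1` gives 58% in this assay.

Of the two measured compounds, compound 1 stands lowest, with compound 2 showing a number 24 percentage points higher from compound 1 to compound 2 (beyond the scatter). Compound 3 `Cc1cc(O)c(C(C)C)cc1-c1cc(-c2ccco2)c(C#N)c(=O)[nH]1` has not been measured; it differs from compound 1 in one place: furan-2-yl in place of 2-chlorophenyl on an aromatic carbon. Among the measured compounds shown here, no measured step exchanges the 2-chlorophenyl group for a five-membered aromatic ring with one hetero atom, so the only guide is that the one known change at this place, from compound 1 to compound 2, moved the number modestly upwards. Nothing shows whether a furan-2-yl group acts like a 2,4-dimethoxyphenyl group, and the expectation is therefore centred close to compound 1 with a wide range. Compound 3 is estimated to give 40% (range 15% to 70%) in this assay. That estimate means a step of a number 6 percentage points higher from compound 1 to compound 3 (within the scatter), which is expected to stay within the usual scatter.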

Compound 3, a percentage reported as inhibition, at one concentration (the size of the read-out at that concentration, not a potency): 70%
Compound 3: middle estimate off by 30 percentage points, on the low side; low and high end bracket the measured number.
By their numbers in this assay, from the lowest: compound 1; then compound 2; then compound 3.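

Placing furan-2-yl on this aromatic carbon instead of 2-chlorophenyl gives a number 36 percentage points higher from compound 1 to compound 3 (beyond the scatter) in this assay, so a five-membered aromatic ring with fewer heavy atoms is not only accepted here but also gives a much higher number. Furan-2-yl also outperforms 2,4-dimethoxyphenyl at the same place, with a number 12 percentage points higher from compound 2 to compound 3 (beyond the scatter) in this assay, which shows that the earlier gain with 2,4-dimethoxyphenyl did not mark the upper limit for this position. Nothing measured here explains why these groups differ.

The compounds shown leave open whether the higher number goes with the ring oxygen or with the smaller ring, a question that thiophene-2-yl and plain phenyl at this place could help to settle. They also leave potency open, since each compound has a read-out at only one concentration.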